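This account rests on a few compounds, and the source may have more. Where it says the series, first, only, none or still open, it means among the compounds named here.

Compound 3 `CC(=O)c1cc(/C=C/c2ccccc2)cc2cc(-c3ccccc3)[nH]c12` and compound 4 `CC(=O)c1cc(/C=C/c2ccccc2)cc2cc(-c3ccc(F)cc3)[nH]c12` share a core, and compound 4 carries a change that has already been tried once, between compound 1 `CC(=O)c1cc(-c2ccccc2)cc2cc(-c3ccccc3)[nH]c12` and compound 2 `CC(=O)c1cc(-c2ccc(F)cc2)cc2cc(-c3ccccc3)[nH]c12`: fluoro in place of hydrogen on an aromatic carbon. In a functional assay on HeLa cells (Homo sapiens) for cytotoxicity, read by MTT assay, with a stated time of 2 days, tested at 1 uM (on this read-out lower numbers stand for a stronger effect and higher numbers for a weaker effect at the one concentration tested), compound 1 gives 65.8%, while compound 2 gives 82.7%, a step of a number 16.9 percentage points higher from compound 1 to compound 2 (beyond the scatter). In this assay compound 3 gives 79.8%; its core differs from that of compound 1 by 2-phenylethenyl in place of phenyl on an aromatic carbon, giving a number 14 percentage points higher from compound 1 to compound 3 (beyond the scatter), while a number 2.9 percentage points lower from compound 2 to compound 3 (within the scatter). The change to compound 4 is fluoro in place of hydrogen on an aromatic carbon, at a place described in the same words as before, so it is the same change. For the measured compounds named here, for compound 4 the expected step is a number 6.2 percentage points higher from compound 3 to compound 4 (within the scatter), resting on the single measured example a number 16.9 percentage points higher from compound 1 to compound 2 (beyond the scatter), which is thin ground, the more so as the numbers already lie high. Compound 4 is expected at about 86%, between 72% and 100%.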

Compound 4, a percentage reported as activity, at one concentration (the size of the read-out at that concentration, not a potency): 60.5%
The estimate for compound 4 lay 25.5 percentage points above the measured number, and the stated range ends above it.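

In this assay, fluoro in place of hydrogen gives a number 19.3 percentage points lower from compound 3 to compound 4 (beyond the scatter), which here means a stronger effect at the one concentration tested. The earlier step ran the opposite way, so this change cannot be carried from one core to the other as a fixed step: the same change on two cores in this assay, a number 16.9 percentage points higher (beyond the scatter) from compound 1 to compound 2 and a number 19.3 percentage points lower (beyond the scatter) from compound 3 to compound 4, 36.2 percentage points apart, beyond the scatter of two such steps. For the compounds shown here, with only one pair on each core, this shows no general rule and does not explain why the direction differs.

The compounds shown leave open whether a chloro or a methoxy group in place of the fluoro would follow either step. They also leave open how the fluoro change behaves when a longer alkyl chain replaces 2-phenylethenyl.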